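A few compounds are considered here, and "the series" means these few. Any claim that something is new, unique, unknown or untested is made for them only; others in the source may bear on it.

The study measures cytotoxicity in a functional assay on Daoy cells (Homo sapiens) for cytotoxicity, read by MTT assay, with a stated time of 72 h; a higher number here means a weaker inhibitor, a lower number a stronger inhibitor. Compound 1 is `COc1cc(NC(=O)c2ccc(F)cc2)cc(OC)c1OC`. In this assay compound 1 gives >= 125000 nM, which is a limit of the assay. Two further compounds stand at the same limit. Compound 2 is `COc1cc(NC(=O)c2cccc([N+](=O)[O-])c2)cc(OC)c1OC`. In this assay compound 2 gives >= 125000 nM, a limit. Compound 3 is `COc1ccc([S+]([O-])N(C)c2cc(OC)c(OC)c(OC)c2)cc1`. In this assay compound 3 gives >= 125000 nM, again a limit. Every value obtained so far therefore sits at the limit of >= 125000 nM in this assay, at which 3 of the 3 values shown sit, and compound 1 stands nowhere in particular among them: all three are limits.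

Compound 4, `COc1cc(NC(=O)c2ccc([N+](=O)[O-])cc2)cc(OC)c1OC`, has not yet been measured in this assay. It differs from compound 1 by nitro in place of fluoro on an aromatic carbon. Going by the values given here, no step between two measured compounds is available, so the data give no direction for this change; the only guide is that compound 1 itself yields a limit. Compound 4 is therefore expected to show a step of a number no higher from compound 1 to compound 4 (the limit leaves the size open) of no size beyond the scatter. Compound 4 is estimated at 125000 nM, with a range from 40000 nM to 300000 nM.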

Compound 4, half-maximal inhibitory concentration: 52900 nM
For compound 4 the middle estimate is 2.4-fold (0.37 log units) above the measured one; measured number inside the range.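

In this assay nitro in place of fluoro, para to a large group, gives an at least 2.3-fold lower number from compound 1 to compound 4 (0.37 log units; beyond the scatter) as its step, and compound 4 is the only compound shown with a number that is not a limit. The shared core can therefore give a measured value in this assay once this position carries nitro. Compound 2 also carries a nitro group, at another place on the same ring, yet compound 2 gives >= 125000 nM as a limit, so the presence of nitro alone does not bring a compound off the limit here.

On these data alone, whether an amine, a nitrile or a carboxylic acid at this position would also give a number stays open. The full size of the step also stays open, because compound 1 gives no number, only a limit: the limit of >= 125000 nM in this assay, at which 3 of the 4 values shown sit.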